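This account rests on a few compounds, and the source may have more. Where it says the series, first, only, none or still open, it means among the compounds named here.

Values in an ADME assay for permeability, using PAMPA, at pH 7.4; a lower number here means that the compound crosses the layer more slowly, a higher number that the compound crosses the layer faster:
- compound 1 `CCc1c(C)[nH]c2cc(OC)c(Cl)cc2c1=O`: 57.3 10^-6 cm/s
- compound 2 `COc1cc2[nH]c(C)c(C3CCCCC3)c(=O)c2cc1Cl`: 630 10^-6 cm/s
- compound 3 `COc1cc2[nH]c(C)c(C)c(=O)c2cc1Cl`: 59.2 10^-6 cm/s

Compound 3, at 59.2 10^-6 cm/s, sits level with compound 1, and only compound 2 stands apart from the pair. The next compound to be read in this assay is compound 4 `COc1cc2[nH]c(C)c(Br)c(=O)c2cc1Cl`, which has bromo in place of methyl on an aromatic carbon. That carbon belongs to a six-membered aromatic ring with 1 nitrogen, part of a fused or bridged system of two rings.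

Among the compounds with values here, no bromo compound has been measured, so the steps available are indirect. The two large ones both involve cyclohexyl, which plays no part in this change: an 11-fold higher number from compound 1 to compound 2 (1.04 log units; beyond the scatter) and an 11-fold lower number from compound 2 to compound 3 (1.03 log units; beyond the scatter). They show that the number can move strongly with the group on an aromatic carbon, but they do not size a swap of methyl for bromo. The closest guide is the step without cyclohexyl, a 1.0-fold higher number from compound 1 to compound 3 (0.01 log units; within the scatter). On that basis, no step beyond the scatter is expected, and the estimated step is a 1.2-fold higher number from compound 3 to compound 4 (0.07 log units; within the scatter). For compound 4 the expected value is 70 10^-6 cm/s, with an estimated range of 30 10^-6 cm/s to 165 10^-6 cm/s.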

Compound 4, apparent permeability: 152 10^-6 cm/s
Compound 4: the middle estimate sits 2.2-fold (0.34 log units) below what was measured; the range from low to high includes it.
By their numbers in this assay, from the lowest: compounds 1 and 3 (each within the scatter of the next); then compound 4; then compound 2.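

In this assay, this aromatic carbon responds even to a swap that leaves the heavy-atom count unchanged: methyl to bromo gives a 2.6-fold higher number from compound 3 to compound 4 (0.41 log units; beyond the scatter), whereas the earlier comparison of the two small alkyl compounds stayed within the scatter, at a 1.0-fold higher number from compound 1 to compound 3 (0.01 log units; within the scatter). Thus a step beyond the scatter at this position no longer depends on cyclohexyl, and bromo also stands clear of ethyl, with a 2.7-fold higher number from compound 1 to compound 4 (0.42 log units; beyond the scatter), while remaining short of cyclohexyl, with a 4.1-fold lower number from compound 2 to compound 4 (0.62 log units; beyond the scatter). No available measurement accounts for the place of bromo in this order.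

Still open, on these data alone, is whether chloro or iodo would read with bromo or with the small alkyl compounds, which would show whether this step is particular to bromo or shared among halogens. Also open, as far as these compounds go, is how an amine, a carboxylic acid or a longer chain on the same carbon would read, and whether the reading with cyclohexyl is matched by an open-chain group such as hexyl.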